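Swapping nitro for iodo in a cytotoxic series

The compounds below may be only part of what the source reports. "The series", "measured", "known", "first", "only" and "open" are said of these compounds alone.

Compound 1 `C/C(=N/NC(=S)Nc1ccccc1)c1ccccn1`: 0.18 nM
Compound 2 `CC(=NNC(=S)Nc1cccc(I)c1)c1ccccn1`: 45 nM
Compound 3 `C/C(=N/NC(=S)Nc1cccc([N+](=O)[O-])c1)c1ccccn1`: 38 nM

All three were tested in a functional assay on MCF7 cells (Homo sapiens) for cytotoxicity, read by MTT assay, with a stated time of 48 h; a lower number here means a stronger inhibitor, a higher number a weaker inhibitor. Going by the values given here, the only measured step here, a 210-fold higher number from compound 1 to compound 3 (2.32 log units; beyond the scatter), is large and replaces hydrogen with nitro. Compound 3 therefore stands far from compound 1, but within the scatter of compound 2.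

Compound 4 `C/C(=N/NC(=S)Nc1cccc(I)c1)c1ccccn1` has iodo in place of nitro on an aromatic carbon. The large step says little about this swap. Compound 2, which also carries iodo, gives 45 nM, so no step beyond the scatter is expected in this assay. The expected change is a 1.2-fold higher number from compound 3 to compound 4 (0.07 log units; within the scatter). For compound 4 the estimated value is 45 nM, with an expected range of 15 nM to 130 nM.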

Compound 4, half-maximal inhibitory concentration: 45 nM
For compound 4 middle estimate and measured number coincide at the digits printed; measured number inside the range.
By their numbers in this assay, from the lowest: compound 1; then compounds 3, 2 and 4 (each within the scatter of the next).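

Iodo and nitro at this place on the aromatic ring cannot be told apart in this assay, with a 1.2-fold higher number from compound 3 to compound 4 (0.07 log units; within the scatter). Iodo in place of hydrogen is also a large step, with a 250-fold higher number from compound 1 to compound 4 (2.40 log units; beyond the scatter), so the large loss seen from compound 1 is not tied to nitro alone. The drawing of the double bond shows no effect in this pair, with no change at the digits printed from compound 2 to compound 4 (within the scatter), and only one thing separates them: the fact that one of compounds 2 and 4 is drawn with a defined configuration and the other without, at the place where they differ

Still open, going by these compounds, is whether an amine or a carboxylic acid at this place would stay near these values or return toward compound 1.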